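From compound 1 to compound 4: the sulfonyl substituent

This account rests on a few compounds, and the source may have more. Where it says the series, first, only, none or still open, it means among the compounds named here.

In a physicochemical assay for solubility, measured as kinetic solubility, with a stated time of 24 h, at pH 7.4 (a higher number here means a more soluble compound, a lower number a less soluble compound), compound 1 `O=C(NCc1ccc(S(=O)(=O)c2cc(F)cc(F)c2)cc1)c1cc2ccncc2o1` gives 5900 nM, the second highest of three measured numbers. Compound 2 `O=C(NCc1ccc(S(=O)(=O)c2cc(F)cc(F)c2)cc1)c1cc2cnccc2[nH]1` gives 1600 nM and compound 3 `O=C(NCc1ccc(S(=O)(=O)C2CCOCC2)cc1)c1cc2cnccc2[nH]1` gives 15000 nM.

Compound 4 `CC(C)N1CCC(S(=O)(=O)c2ccc(CNC(=O)c3cc4ccncc4o3)cc2)CC1` keeps the core of compound 1 and carries this change on a sulfonyl sulfur: 1-isopropylpiperidin-4-yl in place of 3,5-difluorophenyl on a sulfonyl sulfur. The step of a 3.7-fold lower number from compound 1 to compound 2 (0.57 log units; beyond the scatter) concerns the group on a carbonyl carbon and does not bear on this change, though it shows that the number also moves with the core.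

Among the compounds with values here, the only measured step at the sulfonyl sulfur, a 9.4-fold higher number from compound 2 to compound 3 (0.97 log units; beyond the scatter), puts oxan-4-yl in place of 3,5-difluorophenyl. On that basis a higher number is expected in this assay, of similar or somewhat smaller size. This rests on a single step, with a different core and a different entering group, so the range is wide.

The expected step is a 6.8-fold higher number from compound 1 to compound 4 (0.83 log units; beyond the scatter). For compound 4 the estimated value is 40000 nM, with an expected range of 12000 nM to 120000 nM.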

Compound 4, solubility: 183000 nM
Estimate against measurement, compound 4: 4.6-fold (0.66 log units) below; the whole stated range lies below it.
By their numbers in this assay, from the lowest: compound 2; then compound 1; then compound 3; then compound 4.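

In this assay, the step of a 31-fold higher number from compound 1 to compound 4 (1.49 log units; beyond the scatter) puts 1-isopropylpiperidin-4-yl in place of 3,5-difluorophenyl on a sulfonyl sulfur, so a non-aromatic ring at this place now goes with a higher number on the core of compound 1 as well. Set beside a 9.4-fold higher number from compound 2 to compound 3 (0.97 log units; beyond the scatter) with oxan-4-yl on a different core, this step cannot be divided between the entering group and the core. Nothing measured here accounts for this rise.

As far as these compounds go, whether a piperidin-4-yl with a free secondary amine, or with acetyl in place of isopropyl, would give a similar number remains open. Also open, from the compounds shown here alone, is the number for oxan-4-yl on the core of compound 1, which would put both entering groups on one core.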